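Terpene thiosemicarbazones against a prostate cell line

The source may hold more compounds than are shown below. What is called first, only, known or untested is meant among the compounds shown, and "the series" means these compounds.

Compound 1 `CC1=CC[C@@H]([C@@](C)(O)CCCC(C)(C)NC(=S)NN)CC1` carries a bare thiosemicarbazide on the shared core; in a functional assay on PCO3 cells (Homo sapiens) for cytotoxicity, read by sulforhodamine B assay (on this read-out lower numbers stand for stronger inhibition of growth and higher numbers for weaker inhibition of growth), compound 1 reaches only the assay limit of > 100000 nM. Compound 2 `CC1=CC[C@@H]([C@@](C)(O)CCCC(C)(C)NC(=S)N/N=C\c2ccccc2Cl)CC1` likewise stops at the limit in this assay, giving > 100000 nM. Compound 3 `CC1=CC[C@@H]([C@@](C)(O)CCCC(C)(C)NC(=S)N/N=C\c2cccc(Cl)c2)CC1` is the only one of the three that yields a number in this assay, with 37800 nM, so it stands alone among the values shown. For the measured compounds named here, the step of an at least 2.6-fold lower number from compound 2 to compound 3 (0.42 log units; beyond the scatter) is the one measured change within the aryl part, while an at least 2.6-fold lower number from compound 1 to compound 3 (0.42 log units; beyond the scatter) shows that the whole aryl hydrazone adds activity and a step that the two limits leave unreadable from compound 1 to compound 2 cannot be read. Compound 4 `CC1=CC[C@@H]([C@@](C)(O)CCCC(C)(C)NC(=S)N/N=C(/C)c2ccccc2)CC1` differs from compound 3 by a group of 9 heavy atoms (8 carbon, 1 nitrogen; one six-membered aromatic ring of carbon only) in place of a group of 9 heavy atoms (7 carbon, 1 nitrogen, 1 chlorine; one six-membered aromatic ring of carbon only), on an amide-type nitrogen. Going by the values given here, no measured step exchanges the chlorine-bearing group for a chlorine-free one, so the direction is open; because an at least 2.6-fold lower number from compound 2 to compound 3 (0.42 log units; beyond the scatter) already crossed the scatter, a shift of similar size in either direction is plausible. Compound 4 is expected at 70000 nM, within 25000 nM to 200000 nM, an estimated step of a 1.9-fold higher number from compound 3 to compound 4 (0.27 log units; within the scatter) leaning toward weaker inhibition.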

Compound 4, concentration for total growth inhibition: > 100000 nM
Compound 4 gave a limit, no number; the forecaster's own chance of this, stated with the estimate: 45%; middle value at least 1.4-fold (0.15 log units) from the limit.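

In this assay, exchanging the group of 9 heavy atoms that carries chlorine for the chlorine-free group of 9 heavy atoms on the amide-type nitrogen gives an at least 2.6-fold higher number from compound 3 to compound 4 (0.42 log units; beyond the scatter). The chlorine-free group therefore does not keep the gain seen with the 3-chlorophenyl group, and among the aryl hydrazones shown only compound 3 gives a number, while compound 2 and compound 4 do not. The steps among compound 1, compound 2 and compound 4 cannot be read, for each of these compounds gives only an assay limit: the limit of > 100000 nM in this assay, at which 3 of the 4 values shown sit.

The step to compound 4 removes the chlorine and adds a carbon at once, and the compounds shown do not separate these two changes. Going by these compounds, whether a 3-bromophenyl or 3-methoxyphenyl group would hold the number of compound 3 also remains open.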